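Removing an aromatic hydroxy group: cytotoxicity expected unchanged

The compounds below may be only part of what the source reports. "The series", "measured", "known", "first", "only" and "open" are said of these compounds alone.

Compound 1 `COC(=O)c1ccc(C)cc1OC(=O)COc1cc(O)c2c(=O)cc(-c3ccccc3)oc2c1` gives 250000 nM in an ADME assay on cells (T-cell, Mus musculus, strain BALB/c) for cytotoxicity, read by MTT assay, with a stated time of 48 h; a higher number here means that more compound is tolerated, a lower number that less compound is tolerated.
Compound 2 `COC(=O)c1cc(O)ccc1OC(=O)COc1cc(O)c2c(=O)cc(-c3ccccc3)oc2c1` gives 263000 nM in this assay.
Compound 3 `COC(=O)c1c(Br)cc(Br)cc1OC(=O)COc1cc(O)c2c(=O)cc(-c3ccccc3)oc2c1` gives 398000 nM in this assay.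

Compound 2 holds the second highest of these three numbers; its nearest neighbour is compound 1, with a 1.1-fold higher number from compound 1 to compound 2 (0.02 log units; within the scatter), and compound 3 also sits within the usual scatter of compound 2. Compound 4 `COC(=O)c1ccccc1OC(=O)COc1cc(O)c2c(=O)cc(-c3ccccc3)oc2c1` differs from compound 2 only as follows: hydrogen in place of hydroxy on an aromatic carbon. For the measured compounds named here, the one measured step on this ring, a 1.1-fold higher number from compound 1 to compound 2 (0.02 log units; within the scatter), exchanged one ring-bearing group for another without moving beyond the scatter, so no step beyond the scatter is expected here: a 1.0-fold higher number from compound 2 to compound 4 (0.01 log units; within the scatter) in this assay. Compound 4 is therefore estimated at 270000 nM, with a range from 130000 nM to 560000 nM.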

Compound 4, half-maximal cytotoxic concentration: 265000 nM
Compound 4: the middle estimate sits 1.0-fold (0.01 log units) above what was measured, within the range that was stated.
By their numbers in this assay, from the lowest: compounds 1, 2, 4 and 3 (each within the scatter of the next).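

In this assay, hydrogen in place of hydroxy gives a 1.0-fold higher number from compound 2 to compound 4 (0.00 log units; within the scatter) and hydrogen in place of methyl gives a 1.1-fold higher number from compound 1 to compound 4 (0.03 log units; within the scatter) on the same ring. The earlier step set one substituted ring against another, whereas compound 4 supplies the ring with neither group. Against that plain ring, neither the hydroxy of compound 2 nor the methyl of compound 1 moves the number beyond the scatter. Going by these compounds, whether an amine, a carboxylic acid or a longer chain on this ring would do the same remains open. No available evidence explains why these numbers stay so close.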